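Methoxy added to the weakest of three pyrazoline amides

The compounds below may be only part of what the source reports. "The series", "measured", "known", "first", "only" and "open" are said of these compounds alone.

Three compounds share one core. Compound 1 `CCC(=O)N1N=C(c2ccccc2)CC1c1ccc(Cl)cc1` gives 200 nM in an assay on isolated protein for inhibition of Amine oxidase [flavin-containing] A (Bos taurus); on this read-out higher numbers stand for weaker inhibition and lower numbers for stronger inhibition. Compound 2 `CCC(=O)N1N=C(c2ccccc2)CC1c1ccc(C)cc1` gives 75900 nM, the highest number of the three, reached by a 380-fold higher number from compound 1 to compound 2 (2.58 log units; beyond the scatter). Compound 3 `CCC(=O)N1N=C(c2ccc(OC)cc2)CC1c1ccc(Cl)cc1` gives 832 nM. The unmeasured compound 4 `CCC(=O)N1N=C(c2ccc(OC)cc2)CC1c1ccc(C)cc1` differs from compound 2 by methoxy in place of hydrogen on an aromatic carbon. Within the data shown here, one measured step bears on this change: a 4.2-fold higher number from compound 1 to compound 3 (0.62 log units; beyond the scatter), a modest rise. The same change on compound 2 is therefore expected to give a step of comparable size in the same direction, a 3.3-fold higher number from compound 2 to compound 4 (0.52 log units; beyond the scatter). Compound 4 is thus estimated at 250000 nM, with a range from 80000 nM to 800000 nM, so high that this assay may report only a limit.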

Compound 4, half-maximal inhibitory concentration: 7240 nM
For compound 4 the middle estimate is 35-fold (1.54 log units) above the measured one; the whole stated range lies above it.
By their numbers in this assay, from the lowest: compound 1; then compound 3; then compound 4; then compound 2.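

In this assay, the phenyl to 4-methoxyphenyl change gives a 10-fold lower number from compound 2 to compound 4 (1.02 log units; beyond the scatter), so its direction depends on whether the core carries chloro or methyl: the same change on two cores in this assay, a 4.2-fold higher number (0.62 log units; beyond the scatter) from compound 1 to compound 3 and a 10-fold lower number (1.02 log units; beyond the scatter) from compound 2 to compound 4, 44-fold (1.64 log units) apart, beyond the scatter of two such steps. Methyl in place of chloro still raises the number with methoxy present, but far less, an 8.7-fold higher number from compound 3 to compound 4 (0.94 log units; beyond the scatter): the same change on two cores in this assay, a 380-fold higher number (2.58 log units; beyond the scatter) from compound 1 to compound 2 and an 8.7-fold higher number (0.94 log units; beyond the scatter) from compound 3 to compound 4, 44-fold (1.64 log units) apart, beyond the scatter of two such steps. The two changes therefore do not simply add up, as the effect of each depends on the other.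

Going by these compounds, whether fluoro or a longer chain such as ethoxy at this position would also lower the number on the methyl core and raise it on the chloro core stays open. Why the two changes interact cannot be read from these four compounds.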